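Adding Fluoro to a Low-Clearance Compound

The source may report more compounds than this note shows. Statements on the series, on what has been measured and on what is new or still open speak of the compounds shown alone.

Measured in an ADME assay on the whole organism (Rattus norvegicus) for pharmacokinetics, at a dose of 1 mg/kg by the intravenous route; a higher number here means faster removal of the compound, a lower number slower removal:
- Compound 1 `CC[C@@H]1C[C@H](C)CC/C=C\[C@@H]2C[C@@]2(C(=O)NS(=O)(=O)C2CC2)NC(=O)[C@@H]2C[C@@H](Oc3ncc(OC)c4ccccc34)CN2C(=O)[C@H]1NC(=O)OC(C)(C)C(F)(F)F`: 5.73 mL/min/kg
- Compound 2 `CC[C@@H]1C[C@H](C)CC/C=C\[C@@H]2C[C@@]2(C(=O)NS(=O)(=O)C2(C)CC2)NC(=O)[C@@H]2C[C@@H](Oc3ncc(OC)c4ccccc34)CN2C(=O)[C@H]1NC(=O)OC(C)(C)C(F)(F)F`: 1.7 mL/min/kg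

Of these two compounds, compound 2 has the lower number, at 1.7 mL/min/kg. Compound 3 `CC[C@@H]1C[C@H](C)CC/C=C\[C@@H]2C[C@@]2(C(=O)NS(=O)(=O)C2(C)CC2)NC(=O)[C@@H]2C[C@@H](Oc3ncc(OC)c4ccc(F)cc34)CN2C(=O)[C@H]1NC(=O)OC(C)(C)C(F)(F)F` has not yet been measured. It carries fluoro in place of hydrogen on an aromatic carbon.

For the measured compounds named here, only one measured step is available, a 3.4-fold lower number from compound 1 to compound 2 (0.53 log units; beyond the scatter). That modest step came from methyl in place of hydrogen on a saturated ring carbon, a different change, so it bears on the new one only weakly. Going by the values given here, no measured step shows what fluoro in place of hydrogen on an aromatic carbon does in this assay, so no direction can be drawn from the data. The expected step is therefore small, within the scatter: a 1.1-fold lower number from compound 2 to compound 3 (0.03 log units; within the scatter). Compound 3 is estimated at 1.6 mL/min/kg, with an expected range of 0.8 mL/min/kg to 3.4 mL/min/kg.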

Compound 3, clearance: 1.2 mL/min/kg
Beside the measured number, compound 3's estimate is 1.3-fold (0.12 log units) above it; low and high end bracket the measured number.
By their numbers in this assay, from the lowest: compounds 3 and 2 (each within the scatter of the next); then compound 1.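

In this assay, fluoro in place of hydrogen on this aromatic carbon gives a 1.4-fold lower number from compound 2 to compound 3 (0.15 log units; within the scatter) and so leaves the read-out of compound 2 essentially where it stood. The earlier step concerned only a methyl on a saturated ring carbon; this one shows that the six-membered aromatic ring of carbon only can carry a fluoro at this position without a shift beyond the scatter. Nothing available explains this outcome.

The compounds shown leave open whether a chloro, a nitrile or an amine on the same aromatic carbon would also keep the number this low. They also leave open whether fluoro would behave the same way in compound 1, which lacks the methyl.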